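Replacing the Chain on the Carbonyl of Compound 3

This account rests on a few compounds, and the source may have more. Where it says the series, first, only, none or still open, it means among the compounds named here.

Measured so far in a functional assay on MCF7 cells (Homo sapiens) for antiproliferative activity, read by MTT assay, with a stated time of 72 h; a lower number here means a stronger inhibitor, a higher number a weaker inhibitor:
- compound 1 `C/C=C/C(=O)Nc1cccc(Oc2nc(Nc3cccc(OC)c3)nc3c2CSCC3)c1` gives 23400 nM
- compound 2 `CC/C=C/C(=O)Nc1cccc(Oc2nc(Nc3cccc(OC)c3)nc3c2CSCC3)c1` gives 24200 nM
- compound 3 `CCC/C=C/C(=O)Nc1cccc(Oc2nc(Nc3cccc(OC)c3)nc3c2CSCC3)c1` gives 32000 nM

These three compounds share one core and differ only in the length of one chain. Compound 3, at 32000 nM in this assay, sits within the usual scatter of the other two. The measured steps to it are a 1.4-fold higher number from compound 1 to compound 3 (0.14 log units; within the scatter) and a 1.3-fold higher number from compound 2 to compound 3 (0.12 log units; within the scatter), so the three numbers cannot be put in a meaningful order.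

Compound 4 `COc1cccc(Nc2nc3c(c(Oc4cccc(NC(=O)C=C(C)C)c4)n2)CSCC3)c1` has not been measured yet. It differs from compound 3 in one place, on a carbonyl carbon whose other neighbour is an amide-type nitrogen: 2-methylprop-1-en-1-yl in place of pent-1-en-1-yl on a carbonyl carbon. In words, 2-methylprop-1-en-1-yl stands in place of pent-1-en-1-yl.

Going by the values given here, no measured compound carries 2-methylprop-1-en-1-yl, so no direct step exists for this group. The nearest guides are the changes on the same chain, a 1.0-fold higher number from compound 1 to compound 2 (0.01 log units; within the scatter) and a 1.3-fold higher number from compound 2 to compound 3 (0.12 log units; within the scatter). With compound 2 and compound 3 moving this little, no change beyond the scatter is expected in this assay, in either direction.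

The estimated move is a 1.3-fold lower number from compound 3 to compound 4 (0.11 log units; within the scatter) and would be too small to read as a real difference.

For compound 4 the estimate is 25000 nM with 12000 nM to 50000 nM as the expected range.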

Compound 4, half-maximal inhibitory concentration: > 50000 nM
Compound 4 ended at the assay's limit; the forecaster's own chance of this, stated with the estimate: 10%; at least 2.0-fold (0.30 log units) between middle value and limit.
By their numbers in this assay, from the lowest: compounds 1, 2 and 3 (each within the scatter of the next). At a limit, above all of these: compound 4.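

In this assay compound 4 stops at a limit of the assay, so it has no exact number, only a bound: the limit of > 50000 nM in this assay, at which 1 of the 4 values shown sits.

Read against that limit, the steps are an at least 2.1-fold higher number from compound 1 to compound 4 (0.32 log units; beyond the scatter) and an at least 2.0-fold higher number from compound 2 to compound 4 (0.31 log units; beyond the scatter), while an at least 1.5-fold higher number from compound 3 to compound 4 (0.19 log units; that floor lies within the scatter) has a floor that cannot be told apart from repeat-measurement noise. Going by these compounds alone, compounds 1, 2 and 3 showed only that lengthening a straight chain on this carbonyl carbon moves the number within the scatter, whereas 2-methylprop-1-en-1-yl gives the first steps at this position that go beyond it, so the position does respond to what is placed there, and the response is a weaker result in two of the three comparisons.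

The compounds shown leave open whether the methyl branch on the double-bonded chain carbon accounts for this change, since only one branched group appears and its true value lies beyond the limit. Also open, on these data alone, is how a plain ethenyl group or a chain carrying an amine on this carbonyl carbon would read in this assay, and whether either would give a lower number than the straight chains.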